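Halogen swap on the hydrazone aryl ring in a urea series

The source may report more compounds than this note shows. Statements on the series, on what has been measured and on what is new or still open speak of the compounds shown alone.

Measured compounds:
compound 1 `CN(C)CCn1cnnc1-c1cc(Oc2ccc(NC(=O)N/N=C/c3ccc(F)cc3F)cc2F)ccn1` — 960 nM
compound 2 `CN(C)CCn1cnnc1-c1cc(Oc2ccc(NC(=O)N/N=C/c3cccc(Cl)c3Cl)cc2F)ccn1` — 130 nM

In a functional assay on HT-29 cells (Homo sapiens) for cytotoxicity, read by MTT assay, with a stated time of 72 h (a lower number here means a stronger inhibitor, a higher number a weaker inhibitor), compound 1 gives 960 nM and compound 2 gives 130 nM. Within the data shown here, compound 2 holds the lowest of the two numbers; the only step measured so far is a 7.4-fold lower number from compound 1 to compound 2 (0.87 log units; beyond the scatter). Compound 3 `CN(C)CCn1cnnc1-c1cc(Oc2ccc(NC(=O)N/N=C/c3cccc(Br)c3)cc2F)ccn1` carries the change (3-bromophenyl in place of 2,3-dichlorophenyl on a carbon with a double bond to nitrogen). Among the measured compounds shown here, no measured step matches this swap of one halogen pattern for another, so the step from compound 1 to compound 2 gives only a rough scale. The step of a 2.3-fold higher number from compound 2 to compound 3 (0.36 log units; beyond the scatter) is expected to be small. Compound 3 is estimated at 300 nM, within 80 nM to 1200 nM.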

Compound 3, half-maximal inhibitory concentration: 380 nM
Estimate against measurement, compound 3: 1.3-fold (0.10 log units) below, within the range that was stated.
By their numbers in this assay, from the lowest: compound 2; then compound 3; then compound 1.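

In this assay, 3-bromophenyl on the carbon with a double bond to nitrogen gives a 2.9-fold higher number from compound 2 to compound 3 (0.47 log units; beyond the scatter) and also a 2.5-fold lower number from compound 1 to compound 3 (0.40 log units; beyond the scatter). All three aryl groups at this place are therefore separated beyond the scatter, and a ring with a single halogen does not hold the highest number, which stays with 2,4-difluorophenyl. No evidence is available to explain this order. The compounds shown leave open how a 3-chlorophenyl or a 3-aminophenyl group would compare at this place, and whether the kind of halogen or its placement on the ring sets the number.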